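A second fluorine on compound 2

The compounds below may be only part of what the source reports. "The series", "measured", "known", "first", "only" and "open" are said of these compounds alone.

Measured so far:
compound 1 `O=C(Nc1ccc(-c2cscn2)cc1)C1CCCN(Cc2cccc(F)c2)C1`: 5000 nM
compound 2 `O=C(Nc1ccc(-c2cscn2)cc1)C1CCCN(Cc2ccc(F)cc2)C1`: 5000 nM

In a functional assay on A-375 cells (Homo sapiens) for activation, with a stated time of 3 days (on this read-out lower numbers stand for an effect already at smaller amounts and higher numbers for an effect only at larger amounts of compound), compound 2 gives 5000 nM, level with compound 1 at 5000 nM at the digits shown. The next structure is compound 3 `O=C(Nc1ccc(-c2cscn2)cc1)C1CCCN(Cc2cc(F)cc(F)c2)C1`, not yet measured. The change is 3,5-difluorophenyl in place of 4-fluorophenyl on a saturated chain carbon bound to an amine nitrogen in a ring: 3,5-difluorophenyl comes in place of 4-fluorophenyl on a saturated chain carbon bound to an amine nitrogen in a ring, and the rest of the molecule stays the same.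

Among the measured compounds shown here, only one measured step bears on this change, at the same place: 4-fluorophenyl in place of 3-fluorophenyl, which gave no change at the digits printed from compound 1 to compound 2 (within the scatter). For the measured compounds named here, no measured compound carries 3,5-difluorophenyl yet, so this is thin support. With only no change at the digits printed from compound 1 to compound 2 (within the scatter) to go on, no step beyond the scatter, in either direction, is expected in this assay.

The estimated change is no change at the digits printed from compound 2 to compound 3 (within the scatter). For compound 3 the expected value is 5000 nM, with an estimated range from 2000 nM to 10000 nM.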

Compound 3, half-maximal effective concentration: 1500 nM
For compound 3 the middle estimate is 3.3-fold (0.52 log units) above the measured one; measured number outside the range, below it.
By their numbers in this assay, from the lowest: compound 3; then compounds 1 and 2 (each within the scatter of the next).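

In this assay this position turned out to be sensitive after all: compounds with a single fluorine, whether 3-fluorophenyl or 4-fluorophenyl, gave no separation, but 3,5-difluorophenyl brings a modest gain, with a 3.3-fold lower number from compound 2 to compound 3 (0.52 log units; beyond the scatter) in place of 4-fluorophenyl. Among the compounds shown here, the same gain appears in the cleaner comparison, where the only change is fluoro in place of hydrogen on an aromatic carbon, giving a 3.3-fold lower number from compound 1 to compound 3 (0.52 log units; beyond the scatter) and showing that a second fluorine on the ring can matter even though relocating a single one did not. Nothing measured here explains why the second fluorine has this effect.

Three compounds cannot show whether the gain depends on having two fluorines or on where they sit, and a 3,4-difluorophenyl group would help to separate those two readings. Also open, as far as these compounds go, is whether the gain is specific to fluorine, which 3,5-dichlorophenyl or 3,5-dimethylphenyl could test, and how an unsubstituted phenyl or a longer chain between the ring nitrogen and the aromatic ring would compare.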